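Swapping a small ring for a phenethyl chain

The source may hold more compounds than are shown below. What is called first, only, known or untested is meant among the compounds shown, and "the series" means these compounds.

Compound 1 `Nc1ccc(Cl)cc1C1=NN(C(=O)C2CC2)CC1` and compound 2 `Nc1cc(Cl)c(Cl)cc1C1=NN(C(=O)C2CC2)CC1` share one core; compound 2 carries a chloro in place of hydrogen on an aromatic carbon. In an assay on isolated protein for inhibition of Nitric oxide synthase, inducible (Homo sapiens), with a stated time of 30 min, tested at 1 mM (on this read-out higher numbers stand for more inhibition at the one concentration tested (going by the name of the read-out) and lower numbers for less inhibition), compound 1 gives 18.9% and compound 2 gives 15.5%; the step of a number 3.4 percentage points lower from compound 1 to compound 2 (within the scatter) lies within the scatter, so compound 2 stands beside compound 1 on these two numbers. Compound 3 `Nc1cc(Cl)c(Cl)cc1C1=NN(C(=O)CCc2ccccc2)CC1` differs from compound 2 by phenethyl in place of cyclopropyl on a carbonyl carbon. Among the measured compounds shown here, no measured step touches that change, so the data give no size for it, and compound 3 is expected to stay near compound 2, with a number 4.5 percentage points higher from compound 2 to compound 3 (within the scatter), estimated at 20% within 5% to 38%.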

Compound 3, a percentage reported as inhibition, at one concentration (the size of the read-out at that concentration, not a potency): 50.2%
Estimate against measurement, compound 3: 30.2 percentage points below; the whole stated range lies below it.
By their numbers in this assay, from the lowest: compounds 2 and 1 (each within the scatter of the next); then compound 3.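

In this assay, the group on the carbonyl carbon matters: phenethyl in place of cyclopropyl gives a number 34.7 percentage points higher from compound 2 to compound 3 (beyond the scatter). Among the compounds shown here, the chloro change between the earlier compounds moved nothing beyond the scatter, so this is the first change here to shift the read-out clearly. Nothing available explains the rise.

The compounds shown do not separate the effect of the aromatic ring from that of the chain carrying it; benzyl or phenylpropyl on the same carbonyl carbon would address this. On these data alone, how an amine at the chain end would read also remains open.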